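Swapping the Hydrazide Aryl Group: Nitrile to Methoxy

The source may hold more compounds than are shown below. What is called first, only, known or untested is meant among the compounds shown, and "the series" means these compounds.

Measured compounds:
compound 1 `Cc1ccccc1C(=O)N(NC(=O)c1ccccc1)C(C)(C)C` — 224 nM
compound 2 `CC(C)(C)N(NC(=O)c1ccccc1)C(=O)c1ccc(Cl)cc1Cl` — 117 nM
compound 3 `CC(C)(C)N(NC(=O)c1cccc(C#N)c1)C(=O)c1ccccc1Cl` — 955 nM

In an assay on cells for agonist activity at ecdysone receptor (Bombyx mori), read by a luciferase reporter, with a stated time of 24 h (on this read-out lower numbers stand for an effect already at smaller amounts and higher numbers for an effect only at larger amounts of compound), compound 3 gives 955 nM, the highest of the three numbers. Its nearest neighbour is compound 1 with 224 nM, and the furthest is compound 2 with 117 nM, both beyond the scatter. Compound 4 `COc1ccc(C(=O)NN(C(=O)c2ccccc2Cl)C(C)(C)C)cc1` is the next compound, not yet measured. It differs from compound 3 at one position: 4-methoxyphenyl in place of 3-cyanophenyl on a carbonyl carbon.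

Within the data shown here, only one step is recorded among the measured compounds, a 1.9-fold lower number from compound 1 to compound 2 (0.28 log units; within the scatter), and it concerns the other carbonyl carbon, so it does not bear on the change from compound 3 to compound 4. Among the measured compounds shown here, compounds 1 and 2 differ from compound 3 in two places each, so their values set a frame but give no direct step. For the measured compounds named here, with no matching precedent, the expectation rests on compound 3 alone, with a wide range. Compound 4 is expected to give 400 nM in this assay, between 100 nM and 1500 nM. This estimate implies an expected step of a 2.4-fold lower number from compound 3 to compound 4 (0.38 log units; beyond the scatter).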

Compound 4, half-maximal effective concentration: 51.3 nM
Beside the measured number, compound 4's estimate is 7.8-fold (0.89 log units) above it, and the stated range ends above it.
By their numbers in this assay, from the lowest: compound 4; then compounds 2 and 1 (each within the scatter of the next); then compound 3.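

In this assay the aryl group on this carbonyl carbon, whose other neighbour is the amide-type nitrogen, proves highly influential: 4-methoxyphenyl in place of 3-cyanophenyl gives a 19-fold lower number from compound 3 to compound 4 (1.27 log units; beyond the scatter). The only earlier step, a 1.9-fold lower number from compound 1 to compound 2 (0.28 log units; within the scatter), concerned the other carbonyl carbon and stayed within the scatter, which makes this the first change shown to move the number beyond it. No measurement at hand accounts for the size of this step.

The step changes both the group and its printed ring number at once, and the compounds shown do not separate those two changes. From the compounds shown here alone, how 3-methoxyphenyl or 4-cyanophenyl would read at this place remains open, as does whether a 4-aminophenyl or a 4-ethoxyphenyl group would keep the low number of compound 4.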